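Leaving the thiophene: a pyrrole in its place

The source may hold more compounds than are shown below. What is called first, only, known or untested is meant among the compounds shown, and "the series" means these compounds.

Measured in a functional assay on MV4-11 cells (Homo sapiens) for inhibition, read by resazurin assay, with a stated time of 72 h (a lower number here means a stronger inhibitor of growth, a higher number a weaker inhibitor of growth), so far
compound 1 `O=C1NCCC12CCN(c1c(Cl)cncc1-c1ccco1)CC2` gives 940 nM
compound 2 `O=C1NCCC12CCN(c1c(Cl)cncc1-c1ccoc1)CC2` gives 750 nM
compound 3 `O=C1NCCC12CCN(c1c(Cl)cncc1-c1ccsc1)CC2` gives 190 nM

Of these three, compound 3 has the lowest number at 190 nM and stands apart from both others by more than the scatter. The next structure, compound 4 `O=C1NCCC12CCN(c1c(Cl)cncc1-c1cc[nH]c1)CC2`, carries 1H-pyrrol-3-yl in place of thiophen-3-yl on an aromatic carbon and keeps the rest of the shared core.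

No pyrrole has been measured, so only the swaps among the five-membered rings can guide the estimate. The closest is thiophen-3-yl in place of furan-3-yl, which gives a 3.9-fold lower number from compound 2 to compound 3 (0.60 log units; beyond the scatter) and leaves the ring attached in the same way. Thiophen-3-yl in place of furan-2-yl gives a 4.9-fold lower number from compound 1 to compound 3 (0.69 log units; beyond the scatter) in turn. The two furans differ little, with a 1.3-fold lower number from compound 1 to compound 2 (0.10 log units; within the scatter) as their step.

Both measured replacements of the thiophene therefore stand higher, and a modest step towards a higher number is expected again, of about the size of a 3.9-fold lower number from compound 2 to compound 3 (0.60 log units; beyond the scatter) or somewhat less. In this assay the estimate for compound 4 is 500 nM with an expected range from 170 nM to 1400 nM as its limits. This expected step is a 2.6-fold higher number from compound 3 to compound 4 (0.42 log units; beyond the scatter) in size.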

Compound 4, concentration for 50% growth inhibition: 1050 nM
Compound 4: middle estimate off by 2.1-fold (0.32 log units), on the low side; low and high end bracket the measured number.
By their numbers in this assay, from the lowest: compound 3; then compounds 2, 1 and 4 (each within the scatter of the next).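

In this assay the pyrrole does not keep what the thiophene achieved, with a 5.5-fold higher number from compound 3 to compound 4 (0.74 log units; beyond the scatter) as the step, so each of the three other rings measured on this aromatic carbon now stands apart from thiophen-3-yl by more than the scatter. The pyrrole cannot be told apart from either furan, with a 1.4-fold higher number from compound 2 to compound 4 (0.15 log units; within the scatter) and a 1.1-fold higher number from compound 1 to compound 4 (0.05 log units; within the scatter) as the steps, so among these four compounds only the sulfur-containing ring separates from the rest, and compound 3 remains the strongest inhibitor of growth. The entry of a hydrogen-bond donor on the 1H-pyrrol-3-yl ring therefore gives no separation from the furans, and nothing available here explains why thiophen-3-yl alone stands apart.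

The compounds shown leave open whether the sulfur itself matters or whether the way the ring is attached also counts, a question that thiophen-2-yl in the same place would address. They also leave open how 1-methyl-1H-pyrrol-3-yl, which lacks the hydrogen on the ring nitrogen, or a six-membered ring such as phenyl would compare on this aromatic carbon of the shared core.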